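The compounds below may be only part of what the source reports. "The series", "measured", "known", "first", "only" and "open" are said of these compounds alone.

In a functional assay on the whole organism (strain Sprague-Dawley) for inhibition, with Rattus norvegicus as the target, read by paw edema, with stated times of 30 min and 1 h, at a dose of 80 mg/kg by the oral route (a higher number here means more inhibition at the dose given (going by the name of the read-out), a lower number less inhibition), compound 1 `Cc1nc2ccccc2c(=O)n1NC(=O)NC1CCCCC1` gives 12%, compound 2 `Cc1nc2ccccc2c(=O)n1NC(=O)NC(C)(C)C` gives 10.4%, and compound 3 `CC(C)(C)NC(=O)Nn1c(CO[N+](=O)[O-])nc2ccccc2c1=O` gives 6.4%. On the numbers shown, compound 3 holds the lowest of the three, but the two steps that lead to it, a number 1.6 percentage points lower from compound 1 to compound 2 (within the scatter) and a number 4 percentage points lower from compound 2 to compound 3 (within the scatter), both lie within the scatter, so the three compounds cannot be placed in any order in this assay on this evidence.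

Compound 4 `O=C(NC1CCCCC1)Nn1c(CO[N+](=O)[O-])nc2ccccc2c1=O` has not yet been measured in this assay. It differs from compound 3 in one place:

cyclohexyl in place of tert-butyl on an amide-type nitrogen

Among the measured compounds shown here, the only measured step that bears on this exchange is the one between compound 1 and compound 2, which runs in the opposite direction, tert-butyl in place of cyclohexyl on an amide-type nitrogen, and gave a number 1.6 percentage points lower from compound 1 to compound 2 (within the scatter). Turned round, that history suggests at most a small rise and no step beyond the scatter; the step expected here is therefore a number 1.6 percentage points higher from compound 3 to compound 4 (within the scatter). On that basis compound 4 is estimated to give 8% in this assay, with a range from 0% to 18%.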

Compound 4, a percentage reported as inhibition, in the whole organism at one dose (the size of the read-out at that dose, not a potency): 8%
For compound 4 middle estimate and measured number coincide at the digits printed; measured number inside the range.
By their numbers in this assay, from the lowest: compounds 3, 4, 2 and 1 (each within the scatter of the next).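

In this assay, the exchange on the amide-type nitrogen can now be read on a second core, the one carrying nitrooxy, and a number 1.6 percentage points higher from compound 3 to compound 4 (within the scatter) matches the earlier step in size: the same change on two cores in this assay, a number 1.6 percentage points lower (within the scatter) from compound 1 to compound 2 and a number 1.6 percentage points lower (within the scatter) from compound 4 to compound 3, 0 percentage points apart, within the scatter of two such steps The nitrooxy in place of hydrogen on the saturated chain carbon bound to an aromatic carbon can likewise now be read with cyclohexyl as well as with tert-butyl, giving a number 4 percentage points lower from compound 1 to compound 4 (within the scatter), and the two readings agree: the same change on two cores in this assay, a number 4 percentage points lower (within the scatter) from compound 2 to compound 3 and a number 4 percentage points lower (within the scatter) from compound 1 to compound 4, 0 percentage points apart, within the scatter of two such steps The four compounds thus close a square in which neither change alters the size of the other's step, but every step stays within the scatter, so neither group can be said to change the inhibition of paw edema at this dose.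

From the compounds shown here alone, whether any other group on the amide-type nitrogen, such as phenyl or a longer chain, or an amine or a carboxylic acid in place of nitrooxy on the chain carbon, would give a step beyond the scatter remains open. Going by these compounds, what these four compounds would give at another dose remains open as well.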